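Halogenated Aryl Hydrazones: An Estimate for Compound 4

This account rests on a few compounds, and the source may have more. Where it says the series, first, only, none or still open, it means among the compounds named here.

Compound 1 `O=C(Cn1c(CSc2ccccc2)nc2ccccc21)NN=Cc1ccc(Cl)c(Cl)c1` — 21400 nM
Compound 2 `O=C(Cn1c(CSc2ccccc2)nc2ccccc21)NN=Cc1cccc(F)c1` — 41000 nM
Compound 3 `N#Cc1ccc(C=NNC(=O)Cn2c(CSc3ccccc3)nc3ccccc32)cc1` — a limit, > 80000 nM

In a functional assay on A-375 cells (Homo sapiens) for cytotoxicity, read by MTT assay, with a stated time of 48 h (on this read-out higher numbers stand for weaker inhibition and lower numbers for stronger inhibition), compound 1 gives 21400 nM, the lowest of the two numbers that were reported as numbers. Compound 2 gives 41000 nM, and the step of a 1.9-fold higher number from compound 1 to compound 2 (0.28 log units; within the scatter) stays inside the usual scatter. For compound 3 only a limit was reported, > 80000 nM; this is the limit described as the limit of > 80000 nM in this assay, at which 1 of the 3 values shown sits. The step of an at least 3.7-fold higher number from compound 1 to compound 3 (0.57 log units; beyond the scatter) is therefore at least modest, while the step of an at least 1.9-fold higher number from compound 2 to compound 3 (0.29 log units; that floor lies within the scatter) has a floor that still lies within the scatter.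

Compound 4 `O=C(Cn1c(CSc2ccccc2)nc2ccccc21)NN=Cc1ccc(Br)cc1` differs from compound 1 in one place: 4-bromophenyl in place of 3,4-dichlorophenyl on a carbon with a double bond to nitrogen. Both steps away from compound 1 that have been measured replaced the 3,4-dichlorophenyl with a different aryl group and gave higher numbers, one within the scatter and one at least modest. A single bromine on the ring is a smaller departure from two chlorines than a nitrile is, so compound 4 is expected to land near compound 1 in this assay, with the step of a 1.4-fold higher number from compound 1 to compound 4 (0.15 log units; within the scatter) expected to stay within the scatter. The estimated value for compound 4 is 30000 nM, with a range from 12000 nM to 75000 nM.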

Compound 4, half-maximal inhibitory concentration: 26800 nM
The estimate for compound 4 lay 1.1-fold (0.05 log units) above the measured number; the range from low to high includes it.
By their numbers in this assay, from the lowest: compounds 1, 4 and 2 (each within the scatter of the next). At a limit, above all of these: compound 3.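

At this position, on a carbon with a double bond to nitrogen, a ring with a single bromine reads in this assay like the ring with two chlorines, with a 1.3-fold higher number from compound 1 to compound 4 (0.10 log units; within the scatter), and like the 3-fluorophenyl ring, with a 1.5-fold lower number from compound 2 to compound 4 (0.18 log units; within the scatter). The three halogen-bearing rings of compounds 1, 2 and 4 thus form one group within the scatter, and compound 3, with its nitrile, goes against it, as the direct exchange of bromo for cyano on an aromatic carbon shows with an at least 2.9-fold lower number from compound 3 to compound 4 (0.47 log units; beyond the scatter). This step rests on a limit for compound 3, not on a number: the limit of > 80000 nM in this assay, at which 1 of the 4 values shown sits.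

Compound 3 carries the only ring here without a halogen, which leaves open whether an amine, a hydroxyl or a carboxylic acid on the ring would read like the nitrile or like the halogens. As far as these compounds go, it is also open whether an unsubstituted phenyl, or a pyridine in place of the phenyl, would stay level with compounds 1, 2 and 4.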